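Working notes on the aryl-substituent series, compound 3

This account rests on a few compounds, and the source may have more. Where it says the series, first, only, none or still open, it means among the compounds named here.

Among the compounds with values here, compound 2 `COc1cccc(OC)c1C(=O)Nc1nnc(-c2ccc(C#N)cc2)s1` stands highest of the two numbers so far in a functional assay on the whole organism (integument) for inhibition, with Chilo suppressalis as the target, read by scintillation counting, with a stated time of 72 h, in the presence of a further agent that is not named here (a higher number here means a weaker inhibitor, a lower number a stronger inhibitor), where compound 2 gives 200 nM. Compound 1 `COc1cccc(OC)c1C(=O)Nc1nnc(-c2ccc(C(F)(F)F)cc2)s1` gives 56.2 nM; the step of a 3.6-fold higher number from compound 1 to compound 2 (0.55 log units; beyond the scatter) is modest but beyond the scatter. Compound 3 `COc1cccc(OC)c1C(=O)Nc1nnc(-c2ccc(-c3ccccc3)cc2)s1` carries phenyl in place of cyano on an aromatic carbon. No measured step covers this change directly; the one step shown concerns a different group on the same carbon, so it informs only weakly. A move back toward the level of compound 1 is expected, with wide uncertainty, as a 2.0-fold lower number from compound 2 to compound 3 (0.30 log units; within the scatter). For compound 3 the expected value is 100 nM, in the range 30 nM to 400 nM.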

Compound 3, half-maximal inhibitory concentration: 117 nM
For compound 3 the middle estimate is 1.2-fold (0.07 log units) below the measured one; the range from low to high includes it.
By their numbers in this assay, from the lowest: compound 1; then compounds 3 and 2 (each within the scatter of the next).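

In this assay this aromatic carbon accepts a whole phenyl ring: the change from cyano gives a 1.7-fold lower number from compound 2 to compound 3 (0.23 log units; within the scatter) and so does not separate the two groups. Against trifluoromethyl the same ring gives a 2.1-fold higher number from compound 1 to compound 3 (0.32 log units; beyond the scatter) and compound 1 keeps the lowest number of the three. Nothing available explains these steps.

Still open, on these data alone, is how an amine, a carboxylic acid or a longer chain on this carbon would compare with trifluoromethyl. As far as these compounds go, it is also open whether a second ring on phenyl would shift the number at all.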